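Replacing the Ethynyl Group of Compound 2

A few compounds are considered here, and "the series" means these few. Any claim that something is new, unique, unknown or untested is made for them only; others in the source may bear on it.

Two close relatives share one core and differ only in the group on a carbonyl carbon. In a functional assay on HCT-116 cells (Homo sapiens) for inhibition, read by MTT assay, with a stated time of 48 h (a lower number here means a stronger inhibitor, a higher number a weaker inhibitor), compound 1 (`CCCCC(=O)N(Cc1ccc(OC)c(O)c1)c1cc(OC)c(OC)c(OC)c1`) gives 170 nM as its half-maximal inhibitory concentration, and compound 2 (`C#CC(=O)N(Cc1ccc(OC)c(O)c1)c1cc(OC)c(OC)c(OC)c1`) gives 310 nM on the same scale. Going by the values given here, compound 2 therefore stands level with the only other number available, as the two values lie within the usual scatter of each other.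

Compound 3 (`CCC/C=C/C(=O)N(Cc1ccc(OC)c(O)c1)c1cc(OC)c(OC)c(OC)c1`) has not yet been measured. It carries pent-1-en-1-yl in place of ethynyl on a carbonyl carbon. Among the compounds with values here, only one measured step bears on this place, the exchange of butyl for ethynyl. Because a 1.8-fold higher number from compound 1 to compound 2 (0.26 log units; within the scatter) stayed within the scatter, no step beyond it is expected in this assay for this new change. Pent-1-en-1-yl is a carbon chain, as is the butyl group of compound 1 (170 nM), so the estimate leans towards that value. The estimated step is a 1.6-fold lower number from compound 2 to compound 3 (0.19 log units; within the scatter) and so no larger than the scatter. The expected value for compound 3 is 200 nM (estimated range 70 nM to 570 nM).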

Compound 3, half-maximal inhibitory concentration: 95 nM
Compound 3: the middle estimate sits 2.1-fold (0.32 log units) above what was measured, within the range that was stated.
By their numbers in this assay, from the lowest: compounds 3, 1 and 2 (each within the scatter of the next, the first and the last beyond it).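

Going by these compounds alone, until now, the only change at this position had stayed within the scatter, so the group on the carbonyl carbon could have seemed to matter little in this assay. Within the data shown here, compound 3 provides the first step beyond the scatter, though a modest one, with a 3.3-fold lower number from compound 2 to compound 3 (0.51 log units; beyond the scatter) when pent-1-en-1-yl replaces ethynyl, which shows that the choice of group here can change the number, while a 1.8-fold lower number from compound 1 to compound 3 (0.25 log units; within the scatter) leaves the two carbon chains, butyl and pent-1-en-1-yl, level with each other, and compound 1 also remains within the scatter of compound 2, so only compound 2 and compound 3 can be told apart. Nothing available explains why the exchange of ethynyl for pent-1-en-1-yl has this effect.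

With these compounds, the effect of the double bond cannot be separated from that of chain length, a separation that a saturated pentyl group on the same carbonyl carbon could provide. As far as these compounds go, how far this position tolerates other kinds of group also remains open, for instance a longer chain, a phenyl ring, or a chain ending in an amine or a carboxylic acid.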